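From morpholin-4-yl to 2-(hydroxymethyl)piperidin-1-yl on the sulfonyl sulfur

The source may report more compounds than this note shows. Statements on the series, on what has been measured and on what is new or still open speak of the compounds shown alone.

In an ADME assay on Vero cells (Chlorocebus sabaeus) for cytotoxicity, read by MTT assay (a lower number here means that less compound is tolerated, a higher number that more compound is tolerated), compound 1 (`Cn1nc(C(F)(F)F)cc1C(=O)Nc1ccc(S(=O)(=O)OC2CCCCC2)cc1`) gives > 300000 nM as a limit of the assay. Compound 2 (`Cn1nc(C(F)(F)F)cc1C(=O)Nc1ccc(S(=O)(=O)N2CCOCC2)cc1`) gives > 300000 nM as a limit as well. Among the compounds with values here, compound 2 therefore has no number of its own, and the series so far amounts to the limit of > 300000 nM in this assay, at which 2 of the 2 values shown sit, with no ranking possible. Within the data shown here, the only measured step is a step that the two limits leave unreadable from compound 1 to compound 2 and offers no size to carry forward. Compound 3 (`Cn1nc(C(F)(F)F)cc1C(=O)Nc1ccc(S(=O)(=O)N2CCCCC2CO)cc1`) has 2-(hydroxymethyl)piperidin-1-yl in place of morpholin-4-yl on a sulfonyl sulfur. The expectation rests on compound 2 and its limit of > 300000 nM alone. The expected change in this assay is a number no higher from compound 2 to compound 3 (the limit leaves the size open) with no step beyond the scatter and no direction foreseen. For compound 3 the estimate is 300000 nM within an expected range of 150000 nM to 600000 nM and another report as a limit is likely.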

Compound 3, half-maximal cytotoxic concentration: 159000 nM
The estimate for compound 3 lay 1.9-fold (0.28 log units) above the measured number; low and high end bracket the measured number.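

In this assay compound 3 is the first compound in the series with a number of its own, so a change on the sulfonyl sulfur now gives a reading inside the range of the assay, while the others remain at a limit: the limit of > 300000 nM in this assay, at which 2 of the 3 values shown sit.
The change to 2-(hydroxymethyl)piperidin-1-yl gives an at least 1.8-fold lower number from compound 2 to compound 3 (0.27 log units; that floor lies within the scatter), and the same group in place of cyclohexyloxy gives an at least 1.8-fold lower number from compound 1 to compound 3 (0.27 log units; that floor lies within the scatter). From the compounds shown here alone, both steps are floors only, so the true size of each remains unknown and no firm drop in tolerance is established.

The compounds shown do not separate the contribution of the hydroxymethyl group from that of the piperidine ring. Piperidin-1-yl without a side chain, or 2-(aminomethyl)piperidin-1-yl, on the same sulfonyl sulfur would bear on that question.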